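The compounds below may be only part of what the source reports. "The series", "measured", "known", "first", "only" and "open" are said of these compounds alone.

Compound 1 `CNC(=O)c1cc(C(=O)N[C@H]2[C@@H]3C[C@H](O)C[C@@H]32)n([C@@H](C)c2cccc(Cl)c2)n1` is the starting point of this account, and compound 4 `CNC(=O)c1cc(C(=O)N[C@H]2[C@@H]3C[C@@H](O)C[C@@H]32)n([C@@H](C)c2cccc(Cl)c2)n1` is its partner. In a physicochemical assay for solubility, measured as kinetic solubility (on this read-out higher numbers stand for higher solubility and lower numbers for lower solubility), compound 1 gives only a limit of the assay, >= 168 ug/mL. Compound 2 `CNC(=O)c1cc(C(=O)N[C@H]2CC[C@H](O)CC2)n([C@@H](C)c2ccc(Cl)cc2)n1` also returns a limit in this assay, >= 132 ug/mL. Compound 3 `CNC(=O)c1cc(C(=O)N[C@H]2CC[C@H](O)CC2)c([C@@H](C)c2ccccc2Cl)o1` returns a limit in this assay as well, >= 242 ug/mL. Compound 1 therefore stands among three compounds that all sit at limits, its own being the limit of >= 168 ug/mL in this assay, at which 1 of the 3 values shown sits, while the others sit at the limit of >= 132 ug/mL in this assay, at which 1 of the 3 values shown sits, and (the limit of >= 242 ug/mL in this assay, at which 1 of the 3 values shown sits); no real number separates them. Compound 4 differs from compound 1 as follows: the two compounds have the same atoms and bonds and differ only in configuration as drawn: 1 of 5 stereo elements differ; a stereocentre at a saturated ring carbon is drawn S in compound 1 and R in compound 4. For the measured compounds named here, no measured step covers such a change, so the expected step from compound 1 to compound 4 in this assay is none beyond the scatter. The estimated step is a number no higher from compound 1 to compound 4 (the limit leaves the size open). Compound 4 is expected to give 168 ug/mL, within 100 ug/mL to 300 ug/mL, most likely once more as a limit.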

Compound 4, solubility: 175 ug/mL
Compound 4: the middle estimate sits 1.0-fold (0.02 log units) below what was measured, and the stated range covers the measured number.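

For the compounds shown here, compound 1 gives only a limit in this assay, and no step from it to compound 4 can be read. The compounds shown leave open whether the S or R configuration at that saturated ring carbon shifts the result in this assay.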